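This account rests on a few compounds, and the source may have more. Where it says the series, first, only, none or still open, it means among the compounds named here.

In a functional assay on the whole organism (strain Kunming) with Mus musculus as the target, in the formalin test, with a stated time of 0.5 h (a lower number here means that less compound is needed, a higher number that more compound is needed for the effect), compound 1 `COc1ccccc1/C=C/C(=O)OC/C=C/c1cc(OC)c(OC)cc1OC` gives 113 mg/kg, compound 2 `COc1cc(OC)c(OC)cc1/C=C/COC(=O)/C=C/c1ccc(Br)cc1` gives 105 mg/kg and compound 3 `COc1cc(OC)c(OC)cc1/C=C/COC(=O)/C=C/c1cccc(Br)c1` gives 113 mg/kg. Compound 3 is level with compound 1 at the digits reported, and compound 2 lies within the scatter of both.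

The next structure is compound 4 `COc1cccc(/C=C/C(=O)OC/C=C/c2cc(OC)c(OC)cc2OC)c1`, with the change methoxy in place of bromo on an aromatic carbon, meta to a large group. Going by the values given here, three measured steps bear on it. The exchange of 2-methoxyphenyl for 3-bromophenyl gives no change at the digits printed from compound 1 to compound 3 (within the scatter), the exchange of 2-methoxyphenyl for 4-bromophenyl gives a 1.1-fold lower number from compound 1 to compound 2 (0.03 log units; within the scatter), and 3-bromophenyl in place of 4-bromophenyl gives a 1.1-fold higher number from compound 2 to compound 3 (0.03 log units; within the scatter). Among the compounds with values here, all three stay within the scatter, although no measured compound yet carries 3-methoxyphenyl. No step beyond the scatter is therefore expected in this assay, and no direction can be called. The expected step is a 1.0-fold lower number from compound 3 to compound 4 (0.01 log units; within the scatter). The estimate for compound 4 is 110 mg/kg, with an expected range of 70 mg/kg to 170 mg/kg.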

Compound 4, dose for half-maximal effect: > 100 mg/kg
Compound 4 ended at the assay's limit; the forecaster's own chance of this, stated with the estimate: 3%; the middle value lies beyond the limit too.
By their numbers in this assay, from the lowest: compounds 2, 1 and 3 (each within the scatter of the next).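

In this assay compound 4 gives > 100 mg/kg as a limit of the assay, not as a number. Its steps from compound 1, compound 2 and compound 3 therefore cannot be read: the limit of > 100 mg/kg in this assay, at which 1 of the 4 values shown sits. The compounds shown leave open whether 3-methoxyphenyl and 3-bromophenyl differ in this assay at all.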